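Notes on the fused-core series: sizing compound 3

The source may hold more compounds than are shown below. What is called first, only, known or untested is meant among the compounds shown, and "the series" means these compounds.

Measured so far:
compound 1 `Cc1cc(C)n(CCOC2CC(=O)Nc3c2c(C)nn3-c2ncnc3nc[nH]c23)n1` — 2000 nM
compound 2 `CCCCCCCCOC1CC(=O)Nc2c1c(C)nn2-c1ncnc2nc[nH]c12` — 388 nM

In a functional assay on HEK293 cells for agonist activity at G-protein coupled receptor 39 (Homo sapiens), read by scintillation proximity assay and inositol phosphate accumulation, with a stated time of 75 min (on this read-out lower numbers stand for an effect already at smaller amounts and higher numbers for an effect only at larger amounts of compound), compound 1 gives 2000 nM and compound 2 gives 388 nM. For the measured compounds named here, compound 2 stands lowest of the two measured numbers; its only neighbour is compound 1, and the single measured step, a 5.2-fold lower number from compound 1 to compound 2 (0.71 log units; beyond the scatter), puts hexyl in place of 3,5-dimethyl-1H-pyrazol-1-yl on a saturated chain carbon, two bonds along the chain from an oxygen on a saturated carbon.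

Compound 3 `Cc1nn(-c2ncnc3nc[nH]c23)c2c1C(C(=O)NCc1ccccc1)CC(=O)N2` differs from compound 2 by benzylcarbamoyl in place of octyloxy on a saturated ring carbon. Going by the values given here, no measured step bears directly on this change: the one step recorded kept the oxygen-linked chain and altered only its end, whereas here the octyloxy chain leaves altogether and an amide carrying an aromatic ring enters. Among the compounds with values here, the only pointer is that compound 1, the analogue with a ring on its side chain, gives the higher number. The expectation is therefore a modest rise, held with a wide range. For compound 3 the estimate is 1000 nM, expected to fall between 250 nM and 4000 nM. This amounts to an expected 2.6-fold higher number from compound 2 to compound 3 (0.41 log units; beyond the scatter).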

Compound 3, half-maximal effective concentration: 2930 nM
Estimate against measurement, compound 3: 2.9-fold (0.47 log units) below; low and high end bracket the measured number.
By their numbers in this assay, from the lowest: compound 2; then compounds 1 and 3 (each within the scatter of the next).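

In this assay, the saturated ring carbon does not tolerate every group of about this size equally: benzylcarbamoyl in place of octyloxy gives a 7.6-fold higher number from compound 2 to compound 3 (0.88 log units; beyond the scatter), so the number here moves with a change of the whole substituent and of its link to the core, not only with a change at the end of an oxygen-linked chain. Against compound 1 the same position gives a 1.5-fold higher number from compound 1 to compound 3 (0.17 log units; within the scatter), so the two groups of 10 heavy atoms, one with a six-membered aromatic ring of carbon only and one with a five-membered aromatic ring with 2 hetero atoms, are not told apart, and among the three compounds only compound 2, whose octyloxy group has no ring, stands at the lower number. Nothing measured here accounts for these differences.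

The compounds shown do not separate the amide link from the benzyl end: an octylcarbamoyl group or a benzyloxy group on this saturated ring carbon would each change only one of the two. Also open, on these data alone, is how a carboxylic acid, an amine or a chain longer than octyloxy would read at this position.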